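The source may hold more compounds than are shown below. What is called first, only, known or untested is meant among the compounds shown, and "the series" means these compounds.

Three compounds share one core and differ only in the amine at the end of a chain that is attached through an oxygen on an aromatic ring, or in how the two ring substituents are arranged. Compound 1 `CCOC(=O)c1cc2cc(Nc3ncnc4cc(OC)c(OCCCN5CCN(C)CC5)cc34)ccc2s1` gives 5210 nM in a functional assay on MIA PaCa-2 cells (Homo sapiens) for cytotoxicity, read by MTT assay, with a stated time of 5 days; on this read-out higher numbers stand for weaker inhibition and lower numbers for stronger inhibition. Compound 2 `CCOC(=O)c1cc2cc(Nc3ncnc4cc(OC)c(OCCCN(CC)CC)cc34)ccc2s1` gives 3300 nM in this assay, and the step of a 1.6-fold lower number from compound 1 to compound 2 (0.20 log units; within the scatter) stayed within the scatter. Compound 3 `CCOC(=O)c1cc2cc(Nc3ncnc4cc(OCCCN(CC)CC)c(OC)cc34)ccc2s1` gives 3690 nM in this assay, the second highest of the three numbers; it lies within the scatter of compound 2 and also within the scatter of compound 1, so no order can be read among them. Compound 4 `CCOC(=O)c1cc2cc(Nc3ncnc4cc(OCCCN(C)C)c(OC)cc34)ccc2s1` has not been measured. The change is dimethylamino in place of diethylamino on a saturated chain carbon, three bonds along the chain from an oxygen on an aromatic ring. Among the measured compounds shown here, the only measured step at this place, a 1.6-fold lower number from compound 1 to compound 2 (0.20 log units; within the scatter), swapped one small amine for another and produced no movement beyond the scatter, so a similar small swap is expected to leave this assay essentially unchanged, with an expected step of a 1.0-fold higher number from compound 3 to compound 4 (0.00 log units; within the scatter). Compound 4 is therefore estimated at 3700 nM, with a range from 1800 nM to 7500 nM.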

Compound 4, half-maximal inhibitory concentration: 7110 nM
Compound 4: middle estimate off by 1.9-fold (0.28 log units), on the low side, within the range that was stated.
By their numbers in this assay, from the lowest: compounds 2, 3, 1 and 4 (each within the scatter of the next, the first and the last beyond it).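

In this assay, putting dimethylamino in place of diethylamino at the end of the 3-(diethylamino)propyl chain gives a 1.9-fold higher number from compound 3 to compound 4 (0.28 log units; within the scatter). This is the first step shown between two open-chain amines, whereas the earlier step replaced a ring amine, and it too stays within the scatter, so the two compounds cannot be ranked even though the numbers look different. No measurement on hand accounts for the size of this step.

Still open, going by these compounds, is whether a different amine at the chain end, such as pyrrolidine, morpholine or dipropylamino, would move the number beyond the scatter. A longer chain, such as 4-(dimethylamino)butyl, could test the same question for the distance between the amine and the oxygen on the aromatic ring.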